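Methyl on the thiophene of the pyrazoline, compound 3 to 4

The source may hold more compounds than are shown below. What is called first, only, known or untested is meant among the compounds shown, and "the series" means these compounds.

Compound 3 `c1csc(C2=NNC(c3ccc(N4CCCCC4)cc3)C2)c1` gives the lowest of the two numbers shown in an ADME assay on PBMC cells (Homo sapiens) for cytotoxicity, with a stated time of 5 days (a lower number here means a stronger inhibitor, a higher number a weaker inhibitor), at 20800 nM. Compound 1 `Cc1csc(C(=O)/C=C/c2ccc(N3CCCCC3)cc2)c1`, the nearest, gives 68800 nM in this assay, a gap beyond the scatter. Compound 2 `O=C(/C=C/c1ccc(N2CCCCC2)cc1)c1ccc(I)s1` in this assay reaches only the limit of > 100000 nM. Among the compounds with values here, the one measured step, an at least 1.4-fold higher number from compound 1 to compound 2 (0.16 log units; that floor lies within the scatter), is therefore only a floor, read against (the limit of > 100000 nM in this assay, at which 1 of the 3 values shown sits), and it concerns an iodine in place of a methyl on the carbonyl-bearing core of compound 1, not the pyrazoline core shared by compound 3.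

Compound 4 `Cc1csc(C2=NNC(c3ccc(N4CCCCC4)cc3)C2)c1` differs from compound 3 by methyl in place of hydrogen on an aromatic carbon. No measured pair shows a methyl in place of hydrogen on this ring, and the floor from compound 1 to compound 2 lies within the scatter, so nothing shown supports a step beyond the scatter in this assay. The expected change is a 1.0-fold higher number from compound 3 to compound 4 (0.00 log units; within the scatter). Compound 4 is therefore estimated at 21000 nM in this assay, within 8000 nM to 55000 nM.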

Compound 4, half-maximal inhibitory concentration: 24400 nM
The estimate for compound 4 lay 1.2-fold (0.07 log units) below the measured number; low and high end bracket the measured number.
By their numbers in this assay, from the lowest: compounds 3 and 4 (each within the scatter of the next); then compound 1. At a limit, above all of these: compound 2.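

In this assay, the step for methyl in place of hydrogen on the shared core is a 1.2-fold higher number from compound 3 to compound 4 (0.07 log units; within the scatter). Thiophen-2-yl and 4-methylthiophen-2-yl therefore stand within the scatter of each other on this core, with the methyl two ring bonds from the ring sulfur. The earlier step on this ring, an at least 1.4-fold higher number from compound 1 to compound 2 (0.16 log units; that floor lies within the scatter), rests on a limit for compound 2 and belongs to the core of compound 1, whereas this step has a measured number at both ends, although nothing shown gives a reason for it.

From the compounds shown here alone, whether a carboxylic acid, an amine or a longer chain at this position would also stay within the scatter remains open. Also open, going by these compounds, is whether methyl in place of hydrogen reads the same way on the core of compound 1.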